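A few compounds are considered here, and "the series" means these few. Any claim that something is new, unique, unknown or untested is made for them only; others in the source may bear on it.

Compound 1 `Clc1cccc(Cn2cc(COc3ccccc3)nn2)c1` and compound 2 `Brc1ccc(Cn2cc(COc3ccccc3)nn2)cc1` are built on one shared core and differ only by the change (4-bromophenyl in place of 3-chlorophenyl on a saturated chain carbon bound to an aromatic nitrogen). In a physicochemical assay, read by spectrophotometry, with a stated time of 30 min (a higher number here means a weaker inhibitor, a lower number a stronger inhibitor), compound 1 gives 27.3 ug/mL, and compound 2 gives 18.3 ug/mL; the step between them is a 1.5-fold lower number from compound 1 to compound 2 (0.17 log units; within the scatter). Compound 3 `Clc1cccc(Cn2cc(COc3c(Cl)cc(Cl)cc3Cl)nn2)c1` rests on a core that differs from the core of compound 1 in a way not broken down here; in this assay compound 3 gives 16.4 ug/mL. Compound 4 `Clc1cc(Cl)c(OCc2cn(Cc3ccc(Br)cc3)nn2)c(Cl)c1` has not been measured yet. It arises from compound 3 by 4-bromophenyl in place of 3-chlorophenyl on a saturated chain carbon bound to an aromatic nitrogen, the same change at the same place that separates compound 1 and compound 2. Because that earlier step was a 1.5-fold lower number from compound 1 to compound 2 (0.17 log units; within the scatter), a step of similar size is expected here, namely a 1.4-fold lower number from compound 3 to compound 4 (0.14 log units; within the scatter) in this assay. Compound 4 is therefore estimated to give 12 ug/mL, expected to fall between 6 ug/mL and 24 ug/mL.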

Compound 4, half-maximal inhibitory concentration: 14 ug/mL
Compound 4: the middle estimate sits 1.2-fold (0.07 log units) below what was measured; measured number inside the range.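

Carried onto the core of compound 3, the change from 3-chlorobenzyl to 4-bromobenzyl gives a 1.2-fold lower number from compound 3 to compound 4 (0.07 log units; within the scatter) in this assay, and on the core of compound 1 the same change gave a 1.5-fold lower number from compound 1 to compound 2 (0.17 log units; within the scatter) in the same assay. Both steps lie within the scatter, so the two cores agree only in that neither shows a change that can be told from repeat-measurement noise, and this does not show that the swap has a real effect or that the two steps truly match. Nothing measured here speaks to what lies behind these numbers.

From the compounds shown here alone, whether an amine or a carboxylic acid on the benzyl group would give a step beyond the scatter remains open. So does whether this change behaves alike on any further core.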